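The compounds below may be only part of what the source reports. "The series", "measured", "known", "first", "only" and "open" are said of these compounds alone.

Measured so far:
- compound 1, `O=c1cc(/C=C/c2ccc(O)cc2)oc2ccccc12`: 1230 nM
- compound 2, `O=c1cc(/C=C/c2ccccc2)oc2cc(O)cc(O)c12`: 40600 nM

In a functional assay, in the presence of a further agent that is not named here (a higher number here means a weaker inhibitor, a lower number a stronger inhibitor), compound 1 gives 1230 nM. In this assay compound 2 gives 40600 nM, the highest of the two numbers; the gap to compound 1 lies beyond the scatter. For the measured compounds named here, the two compounds differ in more than one place, so no single step connects them.

Compound 3, `O=c1cc(/C=C/c2ccc(O)cc2)oc2cc(O)cc(O)c12`, follows from compound 2 by hydroxy in place of hydrogen on an aromatic carbon. It therefore carries the hydroxy on the pendant ring seen in compound 1 together with the two hydroxy groups on the core of compound 2. Going by the values given here, no measured pair separates these features, so the expected size of the step is uncertain. A move toward a lower number is expected, since compound 1, which has this hydroxy, gives 1230 nM. The step from compound 2 to compound 3 is estimated at a 5.1-fold lower number from compound 2 to compound 3 (0.71 log units; beyond the scatter). For compound 3 in this assay the estimate is 8000 nM, within a range of 2000 nM to 30000 nM.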

Compound 3, half-maximal inhibitory concentration: 1210 nM
For compound 3 the middle estimate is 6.6-fold (0.82 log units) above the measured one; the whole stated range lies above it.
By their numbers in this assay, from the lowest: compounds 3 and 1 (each within the scatter of the next); then compound 2.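

In this assay, for the compounds shown here, the change from phenyl to 4-hydroxyphenyl, para to a large group, gives a 34-fold lower number from compound 2 to compound 3 (1.53 log units; beyond the scatter), the first single-place step, and it is large. Both core hydroxy groups are present on each side of this step, so it reads the pendant ring position alone and shows that this position is highly sensitive to the added hydroxy. No data shown give a cause for the size of this step.

Going by these compounds alone, it remains open whether the same step holds on a core without the two hydroxy groups, as no pair here isolates their contribution. On these data alone, it is also open whether the free hydroxy itself is required at this position, which a methoxy group, an amine or a fluorine atom in its place would test.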